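The compounds below may be only part of what the source reports. "The series", "measured", "known", "first", "only" and "open" are said of these compounds alone.

Of the compounds shown here, two with a shared core have been read so far in a physicochemical assay for lipophilicity, read by HPLC, at pH 7.5; on this read-out higher numbers stand for higher lipophilicity and lower numbers for lower lipophilicity. In this assay compound 1 `CCOc1ccccc1-c1ccc(-c2nc3cnccc3c(N[C@H](CC)C(=O)NS(=O)(=O)C3CC3)c2C#N)cc1` gives 2.3. Compound 2 `CCOc1ccccc1-c1ccc(-c2nc3cnccc3c(NC(CC)CNS(=O)(=O)C3CC3)c2C#N)cc1` gives 3.6, the higher of the two numbers. Going by the values given here, the one measured step, a number 1.30 log units higher from compound 1 to compound 2 (beyond the scatter), is large and beyond the scatter. It came from swapping the group on a nitrogen on an aromatic ring, and the next change falls at that same place.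

Compound 3 `CCOc1ccccc1-c1ccc(-c2nc3cnccc3c(N[C@H](CC(C)C)C(N)=O)c2C#N)cc1` keeps the shared core and differs from compound 2 in this way: a group of 8 heavy atoms (6 carbon, 1 nitrogen, 1 oxygen; no ring) in place of a group of 11 heavy atoms (7 carbon, 1 nitrogen, 2 oxygen, 1 sulfur; one three-membered non-aromatic ring of carbon only), on a nitrogen on an aromatic ring. The entering group, 1-carbamoyl-3-methylbutyl, has no ring and no sulfur, whereas the groups in compound 1 and compound 2 both hold sulfur and a three-membered ring. The measured step of a number 1.30 log units higher from compound 1 to compound 2 (beyond the scatter) shows that a swap here can move the number a long way, but it does not show which way this new group will push it. With no clear direction, the expectation is no step beyond the scatter, held with a wide margin. The expected step is a number 0.10 log units higher from compound 2 to compound 3 (within the scatter). For compound 3 the estimate is 3.7, with an expected range from 3.1 to 4.3.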

Compound 3, distribution coefficient: 3.4
Estimate against measurement, compound 3: 0.30 log units above, within the range that was stated.
By their numbers in this assay, from the lowest: compound 1; then compounds 3 and 2 (each within the scatter of the next).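

In this assay the step of a number 0.20 log units lower from compound 2 to compound 3 (within the scatter) shows that 1-carbamoyl-3-methylbutyl, with no ring and no sulfur, reads level with the larger group it replaces, so neither the three-membered ring nor the sulfur is needed on this nitrogen for a number of this size. The step of a number 1.10 log units higher from compound 1 to compound 3 (beyond the scatter) is large, which leaves compound 1 standing apart: two quite different groups give numbers within the scatter of each other, and only the group in compound 1 gives a clearly lower one. No other measurement is available that would explain how these groups produce these numbers.

Compound 3 differs from compound 2 in its chain, its sulfur and its ring all at once, so these compounds cannot tell whether any one of those parts matters alone or whether their contributions offset one another. They also leave open whether a group ending in a carboxylic acid or an amine, or a longer chain than 1-carbamoyl-3-methylbutyl, would fall with compound 1 or with compounds 2 and 3.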